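A ring swap at the end of a side chain

This account rests on a few compounds, and the source may have more. Where it says the series, first, only, none or still open, it means among the compounds named here.

In a functional assay on the whole organism for antagonist activity, with Rattus norvegicus as the target (on this read-out higher numbers stand for an effect only at larger amounts of compound and lower numbers for an effect already at smaller amounts), compound 2 `CN1CCN(CCCCOc2cc(C(=O)N3CCCCc4sccc43)ccc2NC(=O)c2ccccc2-c2ccccc2)CC1` gives < 0.01 mg/kg as a limit and not a number. Compound 1 `O=C(Nc1ccc(C(=O)N2CCCN(Cc3ccccc3)c3sccc32)cc1)c1ccccc1-c1ccccc1` gives > 0.3 mg/kg as a limit too. Compound 3 `COc1cc(C(=O)N2CCCC(N(C)C)c3sccc32)ccc1NC(=O)c1ccccc1-c1ccccc1` gives > 0.3 mg/kg as a limit as well. Compound 2 thus stands alone at the small-dose end of these three. Compound 4 `CN1CCCN(C(=O)CCCOc2cc(C(=O)N3CCCCc4sccc43)ccc2NC(=O)c2ccccc2-c2ccccc2)CC1` carries (4-methyl-1,4-diazepan-1-yl)carbonyl in place of (4-methylpiperazin-1-yl)methyl ((4-methyl-1,4-diazepan-1-yl)carbonyl in place of (4-methylpiperazin-1-yl)methyl on a saturated chain carbon, three bonds along the chain from an oxygen on an aromatic ring) on a saturated chain carbon, three bonds along the chain from an oxygen on an aromatic ring. Among the measured compounds shown here, no measured pair shows what this swap does. The expected step is a modest one toward larger doses, with an at least 2.0-fold higher number from compound 2 to compound 4 (0.30 log units; that floor lies within the scatter) as the estimate. For compound 4 in this assay the estimated dose is 0.02 mg/kg with 0.005 mg/kg to 0.1 mg/kg as the expected range.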

Compound 4, dose for 50% inhibition: 0.008 mg/kg
The estimate for compound 4 lay 2.5-fold (0.40 log units) above the measured number, within the range that was stated.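

Among the compounds shown here, compound 2 has the limit < 0.01 mg/kg and not a number, and no step to compound 4 can be read from it. The compounds shown leave open how much this ring swap moves the dose, or whether it moves it at all.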